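Trimming the chloropropyl chain of compound 3

This account rests on a few compounds, and the source may have more. Where it says the series, first, only, none or still open, it means among the compounds named here.

In a functional assay on M21 cells (Homo sapiens) for cytotoxicity, read by sulforhodamine B assay, with a stated time of 48 h (a higher number here means a weaker inhibitor, a lower number a stronger inhibitor), compound 1 (`Cc1ccccc1OS(=O)(=O)c1ccc(NC(=O)NCCCCl)cc1`) gives 25000 nM, compound 2 (`CCCc1ccccc1OS(=O)(=O)c1ccc(NC(=O)NCCCCl)cc1`) gives 13000 nM, and compound 3 (`O=C(NCCCCl)Nc1ccc(S(=O)(=O)Oc2ccc(O)cc2)cc1`) gives 47000 nM. Compound 3 stands level with compound 1, with a 1.9-fold higher number from compound 1 to compound 3 (0.27 log units; within the scatter), but apart from compound 2, with a 3.6-fold higher number from compound 2 to compound 3 (0.56 log units; beyond the scatter). The remaining pair shows a 1.9-fold lower number from compound 1 to compound 2 (0.28 log units; within the scatter).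

Compound 4 (`CCNC(=O)Nc1ccc(S(=O)(=O)Oc2ccc(O)cc2)cc1`) keeps the 4-hydroxyphenyl group of compound 3 and shortens the chain, 3-chloropropyl to ethyl: hydrogen in place of chloromethyl on a saturated chain carbon, two bonds along the chain from an amide-type nitrogen. This places hydrogen in place of chloromethyl on a saturated chain carbon, two bonds along the chain from an amide-type nitrogen.

Within the data shown here, no measured step touches this chain. Among the measured compounds shown here, every measured compound carries 3-chloropropyl, and every step changes only the group on oxygen, so the steps offer a sense of scale but no direct precedent. The largest of them is the modest 3.6-fold higher number from compound 2 to compound 3 (0.56 log units; beyond the scatter). The data give no firm direction, so only a small expected rise in this assay is allowed for, and the range is kept wide. The estimated change is a 1.4-fold higher number from compound 3 to compound 4 (0.14 log units; within the scatter). For compound 4 the expected value is 65000 nM, with an estimated range of 28000 nM to 150000 nM.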

Compound 4, half-maximal inhibitory concentration: 4300 nM
Compound 4: middle estimate off by 15-fold (1.18 log units), on the high side; the whole stated range lies above it.
By their numbers in this assay, from the lowest: compound 4; then compounds 2, 1 and 3 (each within the scatter of the next, the first and the last beyond it).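

Shortening 3-chloropropyl to ethyl, with the 4-hydroxyphenyl group kept, gives in this assay an 11-fold lower number from compound 3 to compound 4 (1.04 log units; beyond the scatter), a larger step than the biggest one among the changes on oxygen, a 3.6-fold higher number from compound 2 to compound 3 (0.56 log units; beyond the scatter). The chain, the same in compound 1, compound 2 and compound 3, thus proves to be a place where this read-out responds strongly, and compound 4 shows that the chlorine-bearing end is not required for activity in this cell assay. No measurement shown bears on why the step is so large.

The compounds leave open whether the drop in the number follows from losing the chlorine or from shortening the chain, a question that a propyl or a 2-chloroethyl group would address. Also open, from the compounds shown here alone, are whether the step carries over to 2-methylphenyl or 2-propylphenyl on oxygen, and how an amine or a carboxylic acid on the chain would read.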